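A Halogen Swap on a Weak Growth Inhibitor

The source may report more compounds than this note shows. Statements on the series, on what has been measured and on what is new or still open speak of the compounds shown alone.

Measured so far in a functional assay on NCI-H520 cells (Homo sapiens); a higher number here means a weaker inhibitor of growth, a lower number a stronger inhibitor of growth
Compound 1 `O=S(=O)(/C=C/c1ccc(Cl)c(Cl)c1)Cc1ccc(Nc2ncnc3ccccc23)cc1` gives 32000 nM
Compound 2 `O=S(=O)(/C=C/c1ccc(Cl)cc1Cl)Cc1ccc(Nc2ncnc3ccccc23)cc1` gives 12000 nM

Compound 2 (12000 nM) has the lower of the two numbers, which makes it the stronger inhibitor of growth so far. Within the data shown here, the one measured step, with 2,4-dichlorophenyl in place of 3,4-dichlorophenyl, is a 2.7-fold lower number from compound 1 to compound 2 (0.43 log units; beyond the scatter) and counts as modest.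

Compound 3 `O=S(=O)(/C=C/c1ccc(C(F)(F)F)cc1F)Cc1ccc(Nc2ncnc3ccccc23)cc1` has not yet been measured. It changes that same group (2-fluoro-4-(trifluoromethyl)phenyl in place of 2,4-dichlorophenyl on a double-bonded chain carbon bound to a double-bonded chain carbon) with 2-fluoro-4-(trifluoromethyl)phenyl in place of 2,4-dichlorophenyl, on a double-bonded chain carbon bound to a double-bonded chain carbon.

Among the measured compounds shown here, no measured compound carries fluorine or trifluoromethyl, so the direction of the change remains open. For the measured compounds named here, the only guide to its size is the step between different groups, a 2.7-fold lower number from compound 1 to compound 2 (0.43 log units; beyond the scatter) and this suggests a modest shift at most, either way. The expected result in this assay is a 1.3-fold higher number from compound 2 to compound 3 (0.10 log units; within the scatter) and this estimate implies no clear change. The expected value for compound 3 is 15000 nM with an estimated range from 5000 nM to 40000 nM for repeated measurements.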

Compound 3, concentration for 50% growth inhibition: 100000 nM
Estimate against measurement, compound 3: 6.7-fold (0.82 log units) below; measured number outside the range, above it.
By their numbers in this assay, from the lowest: compound 2; then compound 1; then compound 3.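

In this assay the group on the double-bonded chain carbon turns out to have more influence than the two dichlorophenyl compounds suggested, with an 8.3-fold higher number from compound 2 to compound 3 (0.92 log units; beyond the scatter) when 2-fluoro-4-(trifluoromethyl)phenyl replaces 2,4-dichlorophenyl, a larger step than the one between those two chlorinated groups. The further step a 3.1-fold higher number from compound 1 to compound 3 (0.49 log units; beyond the scatter) shows that the new group also falls behind 3,4-dichlorophenyl, which makes compound 3 the weakest inhibitor of growth of the three, with its steps to both others beyond the scatter. The two groups exchanged in the latest step share one six-membered aromatic ring of carbon only and have no hydrogen-bond donors or acceptors, so the large change in number comes with a difference in substituents alone: 11 heavy atoms with fluorine replace 8 with chlorine.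

No measurement is available that explains why the number rose at this position. Because the fluorine and the trifluoromethyl enter together, the compounds shown cannot separate their contributions, and they leave open how this position would respond to a ring carrying an amine or a carboxylic acid.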